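Swapping a carboxy for a bromo on a sulfone ring

The source may report more compounds than this note shows. Statements on the series, on what has been measured and on what is new or still open speak of the compounds shown alone.

Of the compounds shown here, three sharing one core have been measured in a functional assay on K562 cells (Homo sapiens) for inhibition, read by trypan blue exclusion, with a stated time of 72 h; a higher number here means a weaker inhibitor, a lower number a stronger inhibitor. Compound 1 `COC(=O)Cn1c(=O)c(S(=O)(=O)c2ccc(F)cc2F)cc2cnc(Nc3ccc4[nH]ccc4c3)nc21` gives 5000 nM, and compound 2 `Cn1c(=O)c(S(=O)(=O)c2ccc(C(=O)O)cc2)cc2cnc(Nc3ccc4[nH]ccc4c3)nc21` gives 5000 nM, level with compound 1 at the digits shown and together the lowest of the three numbers. Compound 3 `COc1ccc(Nc2ncc3cc(S(=O)(=O)c4ccc(C)cc4)c(=O)n(C)c3n2)cc1` gives 75000 nM, a higher number that lies beyond the scatter. Compound 4 `Cn1c(=O)c(S(=O)(=O)c2ccc(Br)cc2)cc2cnc(Nc3ccc4[nH]ccc4c3)nc21` is not yet measured; it differs from compound 2 in one place: bromo in place of carboxy on an aromatic carbon. Among the compounds with values here, no measured pair shows this exact change, so its size is open. Compound 1 also carries halogen on its sulfone ring and gives 5000 nM. On that basis the step from compound 2 to compound 4 is expected to be no change at the digits printed from compound 2 to compound 4 (within the scatter), nothing beyond the scatter. Compound 4 is therefore estimated at 5000 nM, within a range from 1500 nM to 16000 nM.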

Compound 4, half-maximal inhibitory concentration: 5000 nM
Compound 4: middle estimate and measured number agree at the digits printed; the range from low to high includes it.
By their numbers in this assay, from the lowest: compounds 1, 2 and 4 (each within the scatter of the next); then compound 3.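

Going from 4-carboxyphenyl to 4-bromophenyl gives no change at the digits printed from compound 2 to compound 4 (within the scatter) in this assay at this one position on the sulfone ring, the first direct reading of a change here. Three heavy atoms, including a hydrogen-bond donor and acceptor, leave and one bromine enters, yet the number does not register the exchange. No measurement at hand explains why these two groups read alike. From the compounds shown here alone, whether an amine or a methoxy group at this place would also leave the number unmoved remains open. So does the effect of a longer chain there.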